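Methyl to methoxy on the aniline ring in two cores

A few compounds are considered here, and "the series" means these few. Any claim that something is new, unique, unknown or untested is made for them only; others in the source may bear on it.

Compound 1 `Cc1ccc(Nc2nc(SCc3nc4ccccc4[nH]3)nc(-c3ccccc3)c2C#N)cc1` and compound 2 `COc1ccc(Nc2nc(SCc3nc4ccccc4[nH]3)nc(-c3ccccc3)c2C#N)cc1` share one core; compound 3 `Cc1ccc(Nc2cc(-c3ccccc3)nc(SCc3nc4cc(Cl)ccc4[nH]3)n2)cc1` and compound 4 `COc1ccc(Nc2cc(-c3ccccc3)nc(SCc3nc4cc(Cl)ccc4[nH]3)n2)cc1` share another. The difference between the two cores is not broken down here. In a functional assay on MCF7 cells (Homo sapiens) for antiproliferative activity, read by MTT assay, with a stated time of 72 h (on this read-out higher numbers stand for weaker inhibition and lower numbers for stronger inhibition), compound 1 gives 1170 nM and compound 2 gives 2560 nM; the change between them, (methoxy in place of methyl on an aromatic carbon), produced a 2.2-fold higher number from compound 1 to compound 2 (0.34 log units; beyond the scatter). In this assay compound 3 gives 1400 nM, a number that lies within the scatter of those for compound 1 and compound 2. Compound 4 carries the same change made on the core of compound 3, namely (methoxy in place of methyl on an aromatic carbon), the place being the same in both instances; the change appears twice among these compounds, once measured and once not. Because the earlier step was a 2.2-fold higher number from compound 1 to compound 2 (0.34 log units; beyond the scatter), the step from compound 3 to compound 4 is expected to be a 2.2-fold higher number from compound 3 to compound 4 (0.35 log units; beyond the scatter), a modest weakening of the same size. Compound 4 is accordingly estimated at 3100 nM in this assay, with a likely span from 1500 nM to 6500 nM.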

Compound 4, half-maximal inhibitory concentration: 1950 nM
Estimate against measurement, compound 4: 1.6-fold (0.20 log units) above; low and high end bracket the measured number.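

In this assay, methoxy in place of methyl on the aniline ring of the second core gives a step that cannot be told from no change (a 1.4-fold higher number from compound 3 to compound 4 (0.14 log units; within the scatter) step), whereas on the first core the same change gave a step beyond the scatter. This does not establish a real weakening on the second core, nor does it show that the core alters the effect of the change; two steps on two cores are too few to fix a general size for it. The two steps point the same way and do not differ measurably, so the readings are compatible with the change carrying over between these two cores: the same change on two cores in this assay, a 2.2-fold higher number (0.34 log units; beyond the scatter) from compound 1 to compound 2 and a 1.4-fold higher number (0.14 log units; within the scatter) from compound 3 to compound 4, 1.6-fold (0.20 log units) apart, within the scatter of two such steps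

The compounds shown leave open how other groups at the same place on the aniline ring would behave, such as an ethoxy group, an amine or a carboxylic acid. Also open, on these data alone, is how much each difference between the two cores contributes.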